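Notes on the ester-oxygen substituent in this series

This account rests on a few compounds, and the source may have more. Where it says the series, first, only, none or still open, it means among the compounds named here.

Three compounds share one core. Compound 1 `CC1=C(C(=O)OCc2ccccc2)C(c2ccco2)NC(=O)N1` carries benzyl on the oxygen next to the carbonyl group; in an assay on membranes from HEK293 cells for displacement of a labelled ligand from adenosine receptor A2b (Homo sapiens), read by scintillation counting, with a stated time of 30 min (on this read-out higher numbers stand for weaker inhibition and lower numbers for stronger inhibition), compound 1 gives 887 nM. Compound 2 `CCCC(=O)C1=C(C)NC(=O)NC1c1ccco1` carries propyl directly on the carbonyl carbon, and in this assay compound 2 gives 807 nM. Compound 3 `CC1=C(C(=O)OC2CCCC2)C(c2ccco2)NC(=O)N1` carries cyclopentyl on that oxygen, and in this assay compound 3 gives 577 nM. Compound 3 sits at the low end of the three numbers, but the steps of a 1.5-fold lower number from compound 1 to compound 3 (0.19 log units; within the scatter) and a 1.4-fold lower number from compound 2 to compound 3 (0.15 log units; within the scatter) are both within the scatter, so the three cannot be told apart on these data.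

Compound 4 `CC1=C(C(=O)OCC2CC2)C(c2ccco2)NC(=O)N1` differs from compound 3 in one place: cyclopropylmethyl in place of cyclopentyl on an oxygen next to a carbonyl group. The step that bears most directly on it is a 1.5-fold lower number from compound 1 to compound 3 (0.19 log units; within the scatter), which also exchanged the group on this oxygen and stayed within the scatter; the step of a 1.4-fold lower number from compound 2 to compound 3 (0.15 log units; within the scatter) touched the same part of the molecule and likewise stayed within the scatter. On this basis no step beyond the scatter is expected in this assay for compound 4, in either direction.

The expected step is a 1.0-fold higher number from compound 3 to compound 4 (0.02 log units; within the scatter). For compound 4 the estimated value in this assay is 600 nM, with a range from 250 nM to 1500 nM.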

Compound 4, inhibition constant: 138 nM
Beside the measured number, compound 4's estimate is 4.3-fold (0.64 log units) above it, and the stated range ends above it.
By their numbers in this assay, from the lowest: compound 4; then compounds 3, 2 and 1 (each within the scatter of the next).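

Within the data shown here, compound 4 shows that the group on this oxygen can move the number in this assay: a 4.2-fold lower number from compound 3 to compound 4 (0.62 log units; beyond the scatter) is the first step at this place to lie beyond the scatter, whereas the exchange of benzyl for cyclopentyl did not. The change itself is small by the computed description, with a five-membered ring of carbon leaving and a three-membered ring of carbon entering as cyclopropylmethyl, and the heavy-atom count going from 5 to 4. Compound 4 also separates from the other two compounds, with both a 6.4-fold lower number from compound 1 to compound 4 (0.81 log units; beyond the scatter) and a 5.8-fold lower number from compound 2 to compound 4 (0.77 log units; beyond the scatter) beyond the scatter, and nothing measured here bears on why this exchange gives a step of this size.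

On these data alone, it remains open whether the result follows the cyclopropyl ring itself or the way it is attached, which cyclopropyl directly on the oxygen, cyclobutylmethyl or isobutyl at the same place could separate. As far as these compounds go, it is also open how far the position tolerates other kinds of group, such as a longer chain or a terminal amine on the oxygen next to a carbonyl group.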